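Bromo to amino in compound 2

The source may hold more compounds than are shown below. What is called first, only, known or untested is meant among the compounds shown, and "the series" means these compounds.

Values in a functional assay on A549 cells (Homo sapiens) for antiproliferative activity, read by MTT assay, with a stated time of 48 h (on this read-out higher numbers stand for weaker inhibition and lower numbers for stronger inhibition), so far:
compound 1 `COc1ccc(-c2nc3cccc(-c4cc(OC)c(OC)c(OC)c4)c3o2)cc1` gives 2200 nM
compound 2 `COc1cc(-c2cccc3nc(-c4ccc(Br)cc4)oc23)cc(OC)c1OC` gives > 25000 nM as a limit
compound 3 `COc1cc(-c2cccc3nc(-c4cccc(O)c4)oc23)cc(OC)c1OC` gives 2000 nM
compound 4 `COc1cc(-c2cccc3nc(-c4ccc(N)cc4)oc23)cc(OC)c1OC` is not yet measured

Compound 2 stands at the limit of > 25000 nM in this assay, at which 1 of the 3 values shown sits, and so has no number. The change to compound 4 is amino in place of bromo on an aromatic carbon in words amino in place of bromo on an aromatic carbon, para to a large group.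

For the measured compounds named here, three measured steps bear on it. The two that leave or reach the bromo group are large: an at least 11-fold higher number from compound 1 to compound 2 (1.05 log units; beyond the scatter) and an at least 12-fold lower number from compound 2 to compound 3 (1.09 log units; beyond the scatter). The third, a 1.1-fold lower number from compound 1 to compound 3 (0.04 log units; within the scatter), stays within the scatter. Going by the values given here, no amino compound has been measured, so a large step to a lower number is expected, though with a wide margin. The expected step is an at least 10-fold lower number from compound 2 to compound 4 (1.00 log units; beyond the scatter). Compound 4 is estimated at 2500 nM, within 600 nM to 12000 nM.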

Compound 4, half-maximal inhibitory concentration: 720 nM
Estimate against measurement, compound 4: 3.5-fold (0.54 log units) above; low and high end bracket the measured number.
By their numbers in this assay, from the lowest: compound 4; then compounds 3 and 1 (each within the scatter of the next). At a limit, above all of these: compound 2.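

For compound 2, this assay gives only a limit, not a number: the limit of > 25000 nM in this assay, at which 1 of the 4 values shown sits. At this place on the aromatic ring, amino in place of bromo moves the series from that limit to a measured value, an at least 34-fold lower number from compound 2 to compound 4 (1.54 log units; beyond the scatter). Compound 4 is also the strongest of the four, with a 3.1-fold lower number from compound 1 to compound 4 (0.49 log units; beyond the scatter) and a 2.8-fold lower number from compound 3 to compound 4 (0.44 log units; beyond the scatter), so this position can give more than the methoxy and 3-hydroxyphenyl compounds showed.

Open, on these data alone, is whether a dimethylamino or acetamido group at the same place would keep this gain. Also open, as far as these compounds go, is whether fluoro or chloro would behave like bromo.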